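Permeability step from compound 2 to compound 4

The compounds below may be only part of what the source reports. "The series", "measured", "known", "first", "only" and "open" are said of these compounds alone.

Measured compounds:
compound 1, `CNC(=O)c1cc(C(=O)N[C@H]2CC[C@H](O)CC2)n([C@@H](C)c2cccc(Cl)c2)n1`, 235 nm/s
compound 2, `CNC(=O)c1cc(C(=O)N[C@H]2CC[C@H](O)CC2)c([C@@H](C)c2cccc(C)c2)o1`, 85 nm/s
compound 3, `CNC(=O)c1cc(C(=O)NC2CCOCC2)n([C@@H](C)c2ccccc2)n1`, 270 nm/s

Of the compounds shown here, three have been measured in an ADME assay for permeability; on this read-out higher numbers stand for higher permeability and lower numbers for lower permeability. Compound 1 gives 235 nm/s, compound 3 gives 270 nm/s, and compound 2 gives 85 nm/s. Compound 2 stands lowest of the three; its distance to compound 1 is the nearer one and its distance to compound 3 the further one, and both of those gaps lie beyond the usual scatter. Among the measured compounds shown here, no pair of these measured compounds differs in only one place, so no single step can be read from them.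

Compound 4, `CNC(=O)c1cc(C(=O)N[C@H]2CC[C@H](O)CC2)c([C@@H](C)c2ccccc2Cl)o1`, has not yet been measured. It differs from compound 2 in one place: 2-chlorophenyl in place of 3-methylphenyl on a saturated chain carbon bound to an aromatic carbon and a saturated chain carbon. Because compound 2 gives 85 nm/s in this assay and compound 1, which also carries a chlorophenyl group, gives 235 nm/s, a modest rise is expected, though one that may stay within the scatter. The expected step is a 1.4-fold higher number from compound 2 to compound 4 (0.13 log units; within the scatter). For compound 4 the estimated value in this assay is 115 nm/s, with a range from 55 nm/s to 240 nm/s.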

Compound 4, apparent permeability: 78 nm/s
For compound 4 the middle estimate is 1.5-fold (0.17 log units) above the measured one; low and high end bracket the measured number.
By their numbers in this assay, from the lowest: compounds 4 and 2 (each within the scatter of the next); then compounds 1 and 3 (each within the scatter of the next).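

In this assay, among the compounds shown here, the exchange of 3-methylphenyl for 2-chlorophenyl on a saturated chain carbon bound to an aromatic carbon and a saturated chain carbon gives a 1.1-fold lower number from compound 2 to compound 4 (0.04 log units; within the scatter), the first step in this set that can be read at a single place. It shows that these two groups, each with 7 heavy atoms and neither with any hydrogen-bond donors or acceptors, cannot be told apart on this read-out with the rest of the structure held constant, although the exchange alters both the substituent and its printed ring number, and this one step cannot separate those two changes. No measurement at hand explains this outcome.

For the compounds shown here, it remains open whether the same exchange would give a similar step on the core of compound 1, where no matching pair is available. As far as these compounds go, it is also open whether a group of a different kind on the phenyl ring, such as an amine, a carboxylic acid or a nitrile, would move the number beyond the scatter from that of compound 2.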